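A few compounds are considered here, and "the series" means these few. Any claim that something is new, unique, unknown or untested is made for them only; others in the source may bear on it.

Of the compounds shown here, three have numbers so far. Compound 1 `COc1cc2c(Oc3ccc(NC(=O)c4nnn(-c5ccccc5C(F)(F)F)c4C)cc3F)ccnc2cc1OCCCN1CCCCC1` gives 280 nM in a functional assay on NCI-H460 cells (Homo sapiens) for cytotoxicity, read by MTT assay, with a stated time of 72 h; on this read-out higher numbers stand for weaker inhibition and lower numbers for stronger inhibition; compound 2 `COc1cc2c(Oc3ccc(NC(=O)c4nnn(-c5ccc(F)c(F)c5)c4C(F)(F)F)cc3F)ccnc2cc1OCCCN1CCCCC1` gives 210 nM; compound 3 `COc1cc2c(Oc3ccc(NC(=O)c4nnn(-c5ccccc5Cl)c4C(F)(F)F)cc3F)ccnc2cc1OCCCN1CCN(C)CC1` gives 330 nM. Compound 3 has the highest of the three numbers, but its gaps to compound 1 and to compound 2 both lie within the scatter, so no order among the three is claimed. Compound 4 `COc1cc2c(Oc3ccc(NC(=O)c4nnn(-c5ccc(F)c(F)c5)c4C(F)(F)F)cc3F)ccnc2cc1OCCCN1CCN(C)CC1` is not yet measured. It differs from compound 3 by 3,4-difluorophenyl in place of 2-chlorophenyl on an aromatic nitrogen. Among the measured compounds shown here, no step between measured compounds isolates this change; compound 2 carries the same entering group but differs from compound 3 elsewhere as well, and the two numbers are close. No step beyond the scatter is expected in this assay from compound 3 to compound 4, in either direction. Compound 4 is estimated at 260 nM, with a range from 120 nM to 550 nM. That estimate means a step of a 1.3-fold lower number from compound 3 to compound 4 (0.10 log units; within the scatter).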

Compound 4, half-maximal inhibitory concentration: 230 nM
The estimate for compound 4 lay 1.1-fold (0.05 log units) above the measured number; measured number inside the range.
By their numbers in this assay, from the lowest: compounds 2, 4, 1 and 3 (each within the scatter of the next).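

In this assay the aryl exchange on the aromatic nitrogen, next to the ring atom that bears a trifluoromethyl group, gives (a 1.4-fold lower number from compound 3 to compound 4 (0.16 log units; within the scatter)) and so does not separate 3,4-difluorophenyl from 2-chlorophenyl. With 3,4-difluorophenyl held fixed, 4-methylpiperazin-1-yl in place of piperidin-1-yl gives (a 1.1-fold higher number from compound 2 to compound 4 (0.04 log units; within the scatter)) and does not separate these two chain ends either. No evidence on the cause of either step is available. Open, going by these compounds, is whether a pyridyl or 4-methoxyphenyl ring on the same nitrogen would give a step beyond the scatter.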